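Swapping a ring for an amide on the shared core

The source may hold more compounds than are shown below. What is called first, only, known or untested is meant among the compounds shown, and "the series" means these compounds.

Measured so far:
compound 1, `CC(C)C(c1cnc(N)s1)c1ccc(-c2ccc3cccc(F)c3c2)[nH]c1=O`: 16 nM
compound 2, `CC(C)C(Cc1noc(=O)[nH]1)c1ccc(-c2ccc3cccc(F)c3c2)[nH]c1=O`: 34 nM

In an assay on CHO cells for displacement of a labelled ligand from prostaglandin E2 receptor EP3 subtype (Homo sapiens), read by radioligand binding (on this read-out lower numbers stand for stronger inhibition and higher numbers for weaker inhibition), compound 2 gives the highest of the two numbers; the nearest is compound 1, and the step of a 2.1-fold higher number from compound 1 to compound 2 (0.33 log units; beyond the scatter) is the only measured one. Compound 3, `CC(C)NC(=O)CC(c1ccc(-c2ccc3cccc(F)c3c2)[nH]c1=O)C(C)C`, is not yet measured. It differs from compound 2 by a group of 6 heavy atoms (4 carbon, 1 nitrogen, 1 oxygen; no ring) in place of a group of 6 heavy atoms (2 carbon, 2 nitrogen, 2 oxygen; one five-membered aromatic ring with 3 hetero atoms), on a saturated chain carbon, two bonds along the chain from an aromatic carbon. Among the measured compounds shown here, the one measured step concerns a ring swap on a different chain carbon, so it only hints at how much this region tolerates change: a modest shift there, and compound 3 now trades the ring for an open chain carrying a single hydrogen-bond acceptor. For the measured compounds named here, no measured compound shows the effect of removing the ring at this place, so the expected direction rests on the idea that a larger change than that of compound 2 may cost more. Compound 3 is expected to give roughly 80 nM in this assay, within 25 nM to 250 nM, a step of a 2.4-fold higher number from compound 2 to compound 3 (0.37 log units; beyond the scatter) that is expected to be modest and toward weaker inhibition.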

Compound 3, inhibition constant: 5.8 nM
Compound 3: middle estimate off by 14-fold (1.14 log units), on the high side; measured number outside the range, below it.
By their numbers in this assay, from the lowest: compound 3; then compound 1; then compound 2.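

In this assay, an open isopropylcarbamoyl group can take the place of the five-membered aromatic ring on a saturated chain carbon, two bonds along the chain from an aromatic carbon, with a 5.9-fold lower number from compound 2 to compound 3 (0.77 log units; beyond the scatter), so a ring is not required there for a low number. The comparison with the aminothiazole points the same way: (isopropylcarbamoyl)methyl in place of 2-amino-1,3-thiazol-5-yl gives a 2.8-fold lower number from compound 1 to compound 3 (0.44 log units; beyond the scatter), which makes the group without a ring the one with the lowest number of the three side groups shown on this core. Nothing available explains why the open amide chain does better than either ring.

The compounds shown do not tell whether the amide hydrogen or the isopropyl end of the new group matters, since neither part is varied on its own. An N,N-dimethylamide, a cyclopropylamide or a carboxylic acid at this place would separate those parts and show how far the low number depends on the exact isopropylcarbamoyl group.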